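The compounds below may be only part of what the source reports. "The series", "measured", "known", "first", "only" and "open" are said of these compounds alone.

Measured so far:
compound 1, `O=C1CC(c2ccccc2OCc2ccccc2)Oc2ccccc21`: 91.5%
compound 2, `COCOc1ccccc1C1CC(=O)c2ccccc2O1`: 33.3%
compound 3, `CCOc1ccccc1C1CC(=O)c2ccccc2O1`: 27.7%

In a functional assay on J774.A1 cells (Mus musculus) for inhibition, read by immunoassay, with a stated time of 12 h, tested at 30 uM (a lower number here means less inhibition, a higher number more inhibition at the concentration tested (going by the name of the read-out)), compound 1 stands highest of the three, ahead of compound 2 and compound 3 by steps beyond the scatter. Compound 4, `CCCCOc1ccccc1C1CC(=O)c2ccccc2O1`, differs from compound 1 in one place: propyl in place of phenyl on a saturated chain carbon bound to an oxygen on an aromatic ring. Among the compounds with values here, the steps that bear on this change are a number 58.2 percentage points lower from compound 1 to compound 2 (beyond the scatter) and a number 63.8 percentage points lower from compound 1 to compound 3 (beyond the scatter), both large drops when the phenyl on that saturated chain carbon is exchanged for a small group; the further step a number 5.6 percentage points lower from compound 2 to compound 3 (within the scatter) is within the scatter. Propyl brings more carbons than methyl or methoxy but, like them, no ring, so a drop beyond the scatter is expected, plausibly smaller than those two. The expected step is a number 46.5 percentage points lower from compound 1 to compound 4 (beyond the scatter). Compound 4 is therefore estimated at 45%, range 20% to 75%.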

Compound 4, a percentage reported as inhibition, at one concentration (the size of the read-out at that concentration, not a potency): 42.5%
Beside the measured number, compound 4's estimate is 2.5 percentage points above it; measured number inside the range.
By their numbers in this assay, from the lowest: compounds 3, 2 and 4 (each within the scatter of the next, the first and the last beyond it); then compound 1.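

In this assay, the step of a number 49 percentage points lower from compound 1 to compound 4 (beyond the scatter) shows that propyl on this saturated chain carbon does not stand in for phenyl. Ethyl in place of hydrogen, two bonds along the chain from an oxygen on an aromatic ring, gives a number 14.8 percentage points higher from compound 3 to compound 4 (beyond the scatter) for a modest gain, while propyl in place of methoxy gives a number 9.2 percentage points higher from compound 2 to compound 4 (within the scatter) and leaves those two compounds unseparated. Nothing measured here explains these steps.

Open remains whether a longer chain such as octyl closes the gap to compound 1, or whether a saturated ring such as cyclohexyl does so in place of phenyl.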